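The source may report more compounds than this note shows. Statements on the series, on what has been measured and on what is new or still open speak of the compounds shown alone.

Compound 3 `OCCn1ncc2c(Nc3ccc(OC(F)(F)F)cc3)ncnc21` stands at the edge of what an ADME assay on BaF3 cells (Mus musculus) for cytotoxicity (on this read-out higher numbers stand for an effect only at larger amounts of compound and lower numbers for an effect already at smaller amounts), reports: in this assay compound 3 gives > 10000 nM, which is a limit and not a number. Compound 2 `CCn1ncc2c(Nc3ccc(OC(F)(F)F)cc3)ncnc21` likewise gives > 10000 nM, again a limit. Compound 1 `FC(F)(F)Oc1ccc(Nc2ncnc3c2cnn3C2CCCCC2)cc1` gives 9300 nM. The steps of an at least 1.0-fold higher number from compound 1 to compound 2 (0.03 log units; that floor lies within the scatter) and an at least 1.0-fold higher number from compound 1 to compound 3 (0.03 log units; that floor lies within the scatter) stay within the scatter, while a step that the two limits leave unreadable from compound 2 to compound 3, which follows from the limit of > 10000 nM in this assay, at which 2 of the 3 values shown sit. Compound 4 `CC(C)(C)n1ncc2c(Nc3ccc(OC(F)(F)F)cc3)ncnc21` differs from compound 3 by tert-butyl in place of 2-hydroxyethyl on an aromatic nitrogen. Going by the values given here, no measured step introduces tert-butyl on the aromatic nitrogen, but the steps that swapped cyclohexyl, ethyl and 2-hydroxyethyl there showed nothing beyond the scatter, so no step beyond the scatter is expected in this assay. Compound 4 is therefore expected to give 12000 nM, between 5000 nM and 30000 nM. The expected step is a step that the limit leaves unreadable from compound 3 to compound 4.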

Compound 4, half-maximal effective concentration: 7300 nM
Estimate against measurement, compound 4: 1.6-fold (0.22 log units) above; low and high end bracket the measured number.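

In this assay, tert-butyl on the aromatic nitrogen leaves every readable comparison within the scatter: an at least 1.3-fold lower number from compound 3 to compound 4 (0.13 log units; that floor lies within the scatter) and an at least 1.3-fold lower number from compound 2 to compound 4 (0.13 log units; that floor lies within the scatter) and a 1.3-fold lower number from compound 1 to compound 4 (0.11 log units; within the scatter). Across cyclohexyl, ethyl, 2-hydroxyethyl and tert-butyl, no swap at this position has yet shown a step beyond the scatter. Going by these compounds, the first two steps remain floors, and their full size stays unknown because compound 2 and compound 3 rest on a limit and not a number: the limit of > 10000 nM in this assay, at which 2 of the 4 values shown sit.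

The compounds shown leave open whether an amine or a carboxylic acid in place of the hydroxy of 2-hydroxyethyl would give a step beyond the scatter.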